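Quinazoline anilines: a chloro for a fluoro swap

The compounds below may be only part of what the source reports. "The series", "measured", "known", "first", "only" and "open" are said of these compounds alone.

Measured in a functional assay on U-937 cells (Homo sapiens) for cytotoxicity, read by MTT assay, with a stated time of 48 h; a lower number here means a stronger inhibitor, a higher number a weaker inhibitor:
- Compound 1 `Fc1cccc(-c2nc(Nc3ccccc3)c3cc(F)ccc3n2)c1` gives 45500 nM.
- Compound 2 `COc1ccc(Nc2nc(-c3cccc(F)c3)nc3ccc(F)cc23)cc1` gives 41100 nM.
- Compound 3 `Fc1cccc(-c2nc(Nc3ccccc3F)c3cc(F)ccc3n2)c1` gives only a limit, > 50000 nM.

All three compounds sit near the upper edge of this assay, and compound 3 is the one that reaches it (the limit of > 50000 nM in this assay, at which 1 of the 3 values shown sits). Compound 3 therefore stands at or beyond the others, though the steps to it are small: an at least 1.0-fold higher number from compound 1 to compound 3 (0.04 log units; that floor lies within the scatter) and an at least 1.2-fold higher number from compound 2 to compound 3 (0.08 log units; that floor lies within the scatter) are both within the scatter, as is a 1.1-fold lower number from compound 1 to compound 2 (0.04 log units; within the scatter).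

Compound 4 `Fc1cccc(-c2nc(Nc3cccc(Cl)c3)c3cc(F)ccc3n2)c1` differs from compound 3 by 3-chlorophenyl in place of 2-fluorophenyl on a nitrogen on an aromatic ring. Within the data shown here, the steps that bear on this change are those altering the same ring on the nitrogen, an at least 1.2-fold higher number from compound 2 to compound 3 (0.08 log units; that floor lies within the scatter) and an at least 1.0-fold higher number from compound 1 to compound 3 (0.04 log units; that floor lies within the scatter), and neither moved beyond the scatter. No step beyond the scatter is therefore expected in this assay; the expected step is an at least 1.0-fold lower number from compound 3 to compound 4 (0.01 log units; that floor lies within the scatter). Compound 4 is estimated at 48000 nM, with a range from 30000 nM to 100000 nM, and a fair chance that only a limit is reported.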

Compound 4, half-maximal inhibitory concentration: > 50000 nM
Compound 4 gave a limit, no number; the forecaster's own chance of this, stated with the estimate: 45%; at least 1.0-fold (0.01 log units) between middle value and limit.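

In this assay compound 4 joins compound 3 at the limit of the assay, so the (3-chlorophenyl)amino group, like the (2-fluorophenyl)amino group, yields a limit and no number: the limit of > 50000 nM in this assay, at which 2 of the 4 values shown sit.

The readable steps are an at least 1.2-fold higher number from compound 2 to compound 4 (0.08 log units; that floor lies within the scatter) and an at least 1.0-fold higher number from compound 1 to compound 4 (0.04 log units; that floor lies within the scatter) and neither floor shows a move beyond the scatter. The step from compound 3 to compound 4 cannot be read, as both values are limits.

As far as these compounds go, how far compound 3 and compound 4 lie past the limit stays open. So does whether another group on this ring on the nitrogen, such as an amine or a carboxylic acid, would bring the number in this assay down beyond the scatter.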